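Notes on the step from compound 3 to compound 4

The source may hold more compounds than are shown below. What is called first, only, known or untested is meant among the compounds shown, and "the series" means these compounds.

The series is measured in a functional assay on the whole organism with Rattus norvegicus as the target; a higher number here means that more compound is needed for the effect, a lower number that less compound is needed. Compound 1 `CC(C)c1ccc2nc(N)sc2c1` gives only a limit in this assay, > 10 mg/kg; here the value sits at the limit of > 10 mg/kg in this assay, at which 1 of the 3 values shown sits, and is not a number. Compound 2 `Nc1nc2ccc(SC(F)(F)F)cc2s1` gives 8 mg/kg in this assay, so the change of (trifluoromethyl)sulfanyl in place of isopropyl on an aromatic carbon reads as an at least 1.2-fold lower number from compound 1 to compound 2 (0.09 log units; that floor lies within the scatter), a step within the scatter. Within the data shown here, compound 3 `N=c1sc2cc(OC(F)(F)F)ccc2n1CCS(N)(=O)=O` gives 6 mg/kg in this assay; its value and that of compound 2 sit within the scatter of each other, so compound 3 stands with the two numbers measured so far. The third value shown is that of compound 1, which is a limit and not a number.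

Compound 4 `CNCCn1c(=N)sc2cc(OC(F)(F)F)ccc21` differs from compound 3 by methylamino in place of sulfamoyl on a saturated chain carbon, two bonds along the chain from an aromatic nitrogen. Among the measured compounds shown here, no measured step touches the chain on the aromatic nitrogen; the one measured step concerns an aromatic carbon and is itself within the scatter, so it gives no direction for this change. With no evidence for a shift, the step from compound 3 to compound 4 is expected to be no change at the digits printed from compound 3 to compound 4 (within the scatter), not beyond the scatter. Compound 4 is therefore estimated at 6 mg/kg in this assay, in a range from 2 mg/kg to 18 mg/kg.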

Compound 4, dose for half-maximal effect: > 10 mg/kg
Compound 4: a limit, no number; the forecaster's own chance of this, stated with the estimate: 15%; middle value at least 1.6-fold (0.22 log units) away from the limit.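

In this assay compound 4 gives > 10 mg/kg, which is a limit and not a number, and this is the first reading on the chain that carries the sulfamoyl group to fall there: the limit of > 10 mg/kg in this assay, at which 2 of the 4 values shown sit.

The exchange of 2-sulfamoylethyl for 2-(methylamino)ethyl reads as an at least 1.6-fold higher number from compound 3 to compound 4 (0.22 log units; that floor lies within the scatter), so the size of this step is known only as a floor, and a larger step cannot be told apart from a small one. What is new is that this place on the chain, a saturated chain carbon two bonds along the chain from an aromatic nitrogen, now has a reading at all, and in this one pair methylamino gives no sign of a lower number than sulfamoyl.

On these data alone, how far compound 4 lies past its limit stays open, and with it whether the true step lies beyond the scatter. Also open, as far as these compounds go, is whether the outcome follows the sulfamoyl group specifically or any exchange at this place, which a carboxylic acid, a primary amine or a longer chain ending in sulfamoyl on the same core would help to separate.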